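The source may report more compounds than this note shows. Statements on the series, on what has been measured and on what is new or still open speak of the compounds shown alone.

Compound 1, with the structure `Fc1ccc(-c2nn(-c3ccccc3)cc2-c2nc3ccccc3[nH]2)cc1`, is the starting point. In a functional assay on MCF7 cells (Homo sapiens) for antiproliferative activity, read by MTT assay, with a stated time of 48 h (on this read-out lower numbers stand for stronger inhibition and higher numbers for weaker inhibition), compound 1 gives 3200 nM. Compound 2, with the structure `Fc1ccc(-c2nn(-c3ccccc3)cc2-c2nc3cc(F)ccc3[nH]2)cc1`, carries an added fluoro on the fused ring of the shared core; in this assay compound 2 gives 950 nM, which is a 3.4-fold lower number from compound 1 to compound 2 (0.53 log units; beyond the scatter). The cores of compound 2 and compound 1 differ as follows: hydrogen in place of fluoro on an aromatic carbon. Compound 3, with the structure `Fc1ccc(-c2nn(-c3ccccc3)cc2-c2nc3cc(Cl)ccc3[nH]2)cc1`, gives 2230 nM in this assay, a change of a 1.4-fold lower number from compound 1 to compound 3 (0.16 log units; within the scatter). From compound 2 to compound 3 the difference is chloro in place of fluoro on an aromatic carbon, and it produced a 2.3-fold higher number from compound 2 to compound 3 (0.37 log units; beyond the scatter).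

Compound 4, with the structure `Clc1ccc(-c2nn(-c3ccccc3)cc2-c2nc3ccccc3[nH]2)cc1`, has not yet been measured. From compound 1 to compound 4 the difference is chloro in place of fluoro on an aromatic carbon. Among the measured compounds shown here, this is the same kind of change as the one from compound 2 to compound 3, but not the same: there the place is part of a fused or bridged system of two rings, meta to a fused ring and para to a fused ring, whereas here the place is a six-membered aromatic ring of carbon only, para to a large group. For the measured compounds named here, only one such exchange has been measured, and it sits on a different ring, so the carry-over is uncertain. Because a 2.3-fold higher number from compound 2 to compound 3 (0.37 log units; beyond the scatter) was a modest move toward a higher number, the step from compound 1 to compound 4 is expected to be about a 1.4-fold higher number from compound 1 to compound 4 (0.15 log units; within the scatter) in this assay. Compound 4 is thus estimated to give 4500 nM, with a likely range from 1600 nM to 12000 nM.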

Compound 4, half-maximal inhibitory concentration: 3030 nM
For compound 4 the middle estimate is 1.5-fold (0.17 log units) above the measured one; the measured number falls inside the stated range.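

Replacing fluoro with chloro on the outer ring of compound 1, the change from 4-fluorophenyl to 4-chlorophenyl, gives a 1.1-fold lower number from compound 1 to compound 4 (0.02 log units; within the scatter) in this assay, so this exchange has no readable effect at this place. The same exchange on the fused ring looks larger at first sight, yet the two results cannot be told apart once ordinary measurement scatter is allowed for: the same change on two cores in this assay, a 2.3-fold higher number (0.37 log units; beyond the scatter) from compound 2 to compound 3 and a 1.1-fold lower number (0.02 log units; within the scatter) from compound 1 to compound 4, 2.5-fold (0.39 log units) apart, within the scatter of two such steps. This does not show that the exchange carries over unchanged from one place or core to another, nor that its effect depends on the place, since each result rests on a single pair of compounds and the scatter of two steps is wide enough to hide a real difference or to create an apparent one.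

As far as these compounds go, it remains open how a methoxy group, an amine or a carboxylic acid would behave in place of the halogen on the outer ring, and whether any of them would move the number beyond the scatter. Also open, from the compounds shown here alone, is what chloro at both places would give, and whether the step seen here would hold on a core that carries a different halogen on the fused ring.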